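The source may report more compounds than this note shows. Statements on the series, on what has been measured and on what is new or still open speak of the compounds shown alone.

Working notes on the series. Compound 2 `CCCS(=O)(=O)Nc1ccc(F)c(C(=O)c2n[nH]c3ncc(-c4ccc(S(N)(=O)=O)cc4)cc23)c1F` gives 0.25% in an assay for binding affinity to dual specificity mitogen-activated protein kinase kinase 4 (Homo sapiens), read by KINOMEscan, tested at 100 nM; on this read-out higher numbers stand for a weaker effect at the one concentration tested and lower numbers for a stronger effect; it holds the lowest of the two numbers measured, the nearest being compound 1 `CCCS(=O)(=O)Nc1ccc(F)c(C(=O)c2n[nH]c3ncc(-c4ccc(O)cc4)cc23)c1F` with 0.75%, and a number 0.5 percentage points lower from compound 1 to compound 2 (within the scatter) left that pair within the scatter. Compound 3 `CCCS(=O)(=O)Nc1ccc(F)c(C(=O)c2n[nH]c3ncc(-c4ccc(C(N)=O)cc4)cc23)c1F` is still unmeasured. Relative to compound 2 the change is carbamoyl in place of sulfamoyl on an aromatic carbon. Going by the values given here, the only measured step, sulfamoyl in place of hydroxy on an aromatic carbon, shows this position tolerating exchange without a step beyond the scatter, so no step beyond the scatter is expected here either. For compound 3 the estimated value is 0.6%, range 0.1% to 6%, the expected step being a number 0.4 percentage points higher from compound 2 to compound 3 (within the scatter).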

Compound 3, a percentage reported as activity, at one concentration (the size of the read-out at that concentration, not a potency): 0.15%
Beside the measured number, compound 3's estimate is 0.5 percentage points above it, and the stated range covers the measured number.
By their numbers in this assay, from the lowest: compounds 3, 2 and 1 (each within the scatter of the next).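

Carbamoyl is a third group tolerated at this position, with this assay giving a number 0.1 percentage points lower from compound 2 to compound 3 (within the scatter) and a number 0.6 percentage points lower from compound 1 to compound 3 (within the scatter). Compounds 1, 2 and 3 therefore cannot be ranked on this read-out, and exchanging sulfamoyl for carbamoyl, with one heavy atom and one double bond fewer, produces no step beyond the scatter. Nothing available explains why these groups read alike. Open, from the compounds shown here alone, is whether a carboxylic acid or an amine in place of carbamoyl would also stay within the scatter. Also open, going by these compounds, is whether any group at this position gives a step beyond it.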